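The source may report more compounds than this note shows. Statements on the series, on what has been measured and on what is new or still open speak of the compounds shown alone.

Compound 1 `COc1ccc(CNC(=O)c2cc(-c3cncc(C)c3)ncc2-c2cnccn2)nc1OC` was tested in an assay on CHO cells for antagonist activity at Orexin receptor type 2 (Homo sapiens), read by FLIPR, with a stated time of 5 min (on this read-out lower numbers stand for stronger inhibition and higher numbers for weaker inhibition), where compound 1 gives 109 nM. Among the two measured compounds this is the higher number. Compound 2 `COc1ccc(CNC(=O)c2nc(-c3cncc(C)c3)cnc2-c2ccccc2)nc1OC` differs from compound 1 at several places; in this assay compound 2 gives 31 nM, and the gap between the two lies beyond the scatter.

Compound 3 `COc1ccc(CNC(=O)c2cc(-c3cncc(C)c3)ncc2-c2cnn(C)c2)nc1OC` has not yet been measured. It differs from compound 1 by one exchange: 1-methyl-1H-pyrazol-4-yl in place of pyrazin-2-yl on an aromatic carbon. The entering group matches the leaving one in heavy atoms and in hydrogen-bond acceptors, but a five-membered ring takes the place of a six-membered one. Among the measured compounds shown here, no measured pair shows this kind of swap, so its effect in this assay is unknown. The step is expected to be small, a 1.1-fold higher number from compound 1 to compound 3 (0.04 log units; within the scatter), not clearly beyond the scatter in either direction. Compound 3 is therefore estimated at 120 nM, with a range from 40 nM to 400 nM.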

Compound 3, half-maximal inhibitory concentration: 167 nM
For compound 3 the middle estimate is 1.4-fold (0.14 log units) below the measured one; low and high end bracket the measured number.
By their numbers in this assay, from the lowest: compound 2; then compounds 1 and 3 (each within the scatter of the next).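

In this assay, the place on the core of compound 1 that is ortho to a large group and para to a 5-methylpyridin-3-yl group accepts 1-methyl-1H-pyrazol-4-yl in place of pyrazin-2-yl with a 1.5-fold higher number from compound 1 to compound 3 (0.19 log units; within the scatter). This step lies within the scatter, so for this one pair a five-membered aromatic ring serves here as well as a six-membered one, with heavy atoms and hydrogen-bond acceptors matched in number. No supporting finding is available that would give a reason for this result.

Still open, from the compounds shown here alone, is whether this place needs an aromatic ring at all, or whether a plain methyl, an amine or a carboxylic acid would give a similar number. Also open, going by these compounds, is what the ring's methyl contributes, which the parent 1H-pyrazol-4-yl group would show.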